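Amide aryl change from compound 1 to compound 3

The compounds below may be only part of what the source reports. "The series", "measured", "known", "first", "only" and "open" are said of these compounds alone.

Compound 1 `N#Cc1cccc(C(=O)NCN2CCC(c3cccc[n+]3[O-])CC2)c1` gives 69% in a functional assay on HEK293 cells for agonist activity at D(4) dopamine receptor (Homo sapiens), read by FLIPR (a lower number here means a smaller maximal response, a higher number a larger maximal response), the highest of the two numbers measured. Compound 2 `CCOc1cccc(C(=O)NCN2CCC(c3cccc[n+]3[O-])CC2)c1` gives 54% in this assay; the step of a number 15 percentage points lower from compound 1 to compound 2 (beyond the scatter) goes with ethoxy in place of cyano on an aromatic carbon.

Compound 3 `O=C(NCN1CCC(c2cccc[n+]2[O-])CC1)c1cc(Cl)cc(Cl)c1` differs from compound 1 by 3,5-dichlorophenyl in place of 3-cyanophenyl on a carbonyl carbon. Among the compounds with values here, the single measured step, where the cyano was replaced, lowered the response modestly; a dichlorophenyl has not been measured. A modest decrease in this assay is therefore expected for compound 3, estimated at 57% with a range from 40% to 75%. The expected step is a number 12 percentage points lower from compound 1 to compound 3 (beyond the scatter).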

Compound 3, largest response reached (reported as efficacy), in percent of the reference or control that the assay uses: 64%
Estimate against measurement, compound 3: 7 percentage points below; measured number inside the range.
By their numbers in this assay, from the lowest: compounds 2, 3 and 1 (each within the scatter of the next, the first and the last beyond it).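

The step of a number 5 percentage points lower from compound 1 to compound 3 (within the scatter) in this assay shows that the response does not depend on the nitrile at this place: 3,5-dichlorophenyl, with no hydrogen-bond acceptor, serves on the carbonyl carbon. The ethoxy change, by contrast, gave a number 15 percentage points lower from compound 1 to compound 2 (beyond the scatter) and is the only replacement so far beyond the scatter. Nothing available explains why the two replacements differ.

Open, as far as these compounds go, is whether a single chlorine or an unsubstituted phenyl would serve as well. Also open, from the compounds shown here alone, is how an aryl group carrying a primary amine or a carboxylic acid would respond.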